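The source may hold more compounds than are shown below. What is called first, only, known or untested is meant among the compounds shown, and "the series" means these compounds.

Three compounds share one core and differ only in the group on the amide-type nitrogen. In an assay on HEK293 cells for agonist activity at transient receptor potential cation channel subfamily M member 8 (Homo sapiens), read by fluorescence and calcium flux, with a stated time of 15 min (a lower number here means that less compound is needed, a higher number that more compound is needed for the effect), compound 1 `Cc1ccc(OCC(=O)N(Cc2cccs2)c2ncccn2)cc1` gives 3700 nM, compound 2 `Cc1ccc(OCC(=O)N(Cc2cccs2)CC(C)C)cc1` gives 900 nM, and compound 3 `Cc1ccc(OCC(=O)N(Cc2cccs2)c2ccnn2C)cc1` gives 422 nM, the lowest of the three: the nearest is compound 2 with a 2.1-fold lower number from compound 2 to compound 3 (0.33 log units; beyond the scatter) and the furthest compound 1 with an 8.8-fold lower number from compound 1 to compound 3 (0.94 log units; beyond the scatter). Compound 4 `C=CCN(Cc1cccs1)C(=O)COc1ccc(C)cc1` is not yet measured; it differs from compound 3 by allyl in place of 1-methyl-1H-pyrazol-5-yl on an amide-type nitrogen. The step that bears most on it is a 2.1-fold lower number from compound 2 to compound 3 (0.33 log units; beyond the scatter), which also set a group with no ring against the 1-methyl-1H-pyrazol-5-yl group, and undoing that change should cost a similar amount. For compound 4 the expected step is therefore a 2.8-fold higher number from compound 3 to compound 4 (0.45 log units; beyond the scatter), a rise. Compound 4 is estimated at 1200 nM in this assay, with a range from 400 nM to 4000 nM.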

Compound 4, half-maximal effective concentration: 20 nM
Compound 4: the middle estimate sits 60-fold (1.78 log units) above what was measured, and the stated range ends above it.
By their numbers in this assay, from the lowest: compound 4; then compound 3; then compound 2; then compound 1.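

Within the data shown here, at the amide-type nitrogen in this assay, allyl in place of the 1-methyl-1H-pyrazol-5-yl group gives a 21-fold lower number from compound 3 to compound 4 (1.32 log units; beyond the scatter), a far larger step than any among the earlier compounds, and a 190-fold lower number from compound 1 to compound 4 (2.27 log units; beyond the scatter) now spans this position. Having no ring does not settle the number, for compound 2 also has none, yet vinyl in place of isopropyl on the saturated chain carbon gives a 45-fold lower number from compound 2 to compound 4 (1.65 log units; beyond the scatter). Nothing available explains this result. Still open, as far as these compounds go, is whether the double bond matters, or whether a propyl group or a longer chain ending in a double bond would give as low a number.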